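The source may hold more compounds than are shown below. What is called first, only, known or untested is meant among the compounds shown, and "the series" means these compounds.

Compound 3 `CS(=O)(=O)c1ccc(Nc2ncnc3sc(Nc4c(Cl)cccc4Cl)nc23)cc1` gives the lowest number of the three compounds measured in a functional assay on HEK293 cells for antagonist activity at transient receptor potential cation channel subfamily V member 1 (Rattus norvegicus), read by calcium flux (a lower number here means a stronger inhibitor, a higher number a weaker inhibitor), at 3 nM. Compound 2 `CSc1ccc(Nc2ncnc3sc(Nc4c(Cl)cccc4Cl)nc23)cc1` gives 12 nM, and compound 1 `Clc1cccc(Cl)c1Nc1nc2c(Nc3ccccc3)ncnc2s1` gives 170 nM. The steps among these three compounds are a 14-fold lower number from compound 1 to compound 2 (1.15 log units; beyond the scatter), a 57-fold lower number from compound 1 to compound 3 (1.75 log units; beyond the scatter) and a 4.0-fold lower number from compound 2 to compound 3 (0.60 log units; beyond the scatter). Compound 4 `NS(=O)(=O)c1ccc(Nc2ncnc3sc(Nc4c(Cl)cccc4Cl)nc23)cc1` differs from compound 3 in one place: amino in place of methyl on a sulfonyl sulfur. Among the measured compounds shown here, no measured step alters a group on the sulfonyl sulfur itself; the nearest guide is a 4.0-fold lower number from compound 2 to compound 3 (0.60 log units; beyond the scatter), where exchanging the whole group on the aromatic carbon brought only a modest gain. For compound 4 the number in this assay is therefore expected to stay close to that of compound 3, an estimated step of a 1.3-fold higher number from compound 3 to compound 4 (0.12 log units; within the scatter). Compound 4 is estimated at 4 nM, within a range from 1.5 nM to 12 nM.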

Compound 4, half-maximal inhibitory concentration: 590 nM
Compound 4: the middle estimate sits 150-fold (2.17 log units) below what was measured, and the stated range ends below it.
By their numbers in this assay, from the lowest: compound 3; then compound 2; then compound 1; then compound 4.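

In this assay, exchanging methyl for amino on a sulfonyl sulfur gives a 200-fold higher number from compound 3 to compound 4 (2.29 log units; beyond the scatter), so the group on that sulfur can decide the outcome. Sulfamoyl also compares poorly with methylsulfanyl, with a 49-fold higher number from compound 2 to compound 4 (1.69 log units; beyond the scatter), and even with plain hydrogen on the aromatic carbon, with a 3.5-fold higher number from compound 1 to compound 4 (0.54 log units; beyond the scatter). A sulfur-bearing group there therefore does not guarantee a gain: compound 2 and compound 3 improve on compound 1, while compound 4 goes against them. No measurement shown gives a reason for this drop. As far as these compounds go, whether ethyl or dimethylamino on the sulfonyl sulfur would behave like methyl or like amino remains open.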